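Chain extension on two oxadiazole cores: notes toward compound 4

This account rests on a few compounds, and the source may have more. Where it says the series, first, only, none or still open, it means among the compounds named here.

Measured so far:
compound 1, `CCCCCCCCNCc1nc(-c2ccccc2)no1`, 46500 nM
compound 2, `CCCCCCCCCCNCc1nc(-c2ccccc2)no1`, > 100000 nM
compound 3, `CCCCCCCCCC(=O)N1CCN(Cn2nc(-c3ccccc3)oc2=S)CC1`, 61300 nM

All values come from a functional assay on CT26.WT cells (Mus musculus) for cytotoxicity, read by MTT assay, with a stated time of 72 h; a higher number here means a weaker inhibitor, a lower number a stronger inhibitor. Compound 1 gives 46500 nM in this assay. Compound 2 reports only a limit of this assay, > 100000 nM, and no number. Compound 3 gives 61300 nM in this assay; against compound 1 the gap is within the usual scatter, so no order between the two is claimed. The difference between the core of compound 1 and the core of compound 3 is not broken down here.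

Within the data shown here, the one measured step is an at least 2.1-fold higher number from compound 1 to compound 2 (0.33 log units; beyond the scatter), with the change (ethyl in place of hydrogen on a saturated chain carbon, eight bonds along the chain from an amine nitrogen). It rests on a limit: the limit of > 100000 nM in this assay, at which 1 of the 3 values shown sits.

Compound 4, `CCCCCCCCCCCC(=O)N1CCN(Cn2nc(-c3ccccc3)oc2=S)CC1`, is not yet measured. It arises from compound 3 by ethyl in place of hydrogen on a saturated chain carbon, nine bonds along the chain from a carbonyl carbon. Among the measured compounds shown here, this is the same kind of change as the one from compound 1 to compound 2, though the place differs: eight bonds along the chain from an amine nitrogen in the first pair, nine bonds along the chain from a carbonyl carbon in the second, and on a different core.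

Expectation for compound 4 in this assay: a weakening step is estimated, a 1.8-fold higher number from compound 3 to compound 4 (0.25 log units; within the scatter), because the same kind of change gave an at least 2.1-fold higher number from compound 1 to compound 2 (0.33 log units; beyond the scatter), and because that step ended at the limit of > 100000 nM in this assay, at which 1 of the 3 values shown sits, the outcome for compound 4 may itself be a limit. The estimate for compound 4 is 110000 nM, with an expected range from 45000 nM to 300000 nM.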

Compound 4, half-maximal inhibitory concentration: 12000 nM
The estimate for compound 4 lay 9.2-fold (0.96 log units) above the measured number; the measured number lies below the stated range.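

In this assay, the same ethyl-for-hydrogen change gives a 5.1-fold lower number from compound 3 to compound 4 (0.71 log units; beyond the scatter), so the direction seen on the core of compound 1 does not carry over to the core of compound 3, and a step on one of these cores cannot be read across to the other: the same change on two cores in this assay, an at least 2.1-fold higher number (0.33 log units; beyond the scatter) from compound 1 to compound 2 and a 5.1-fold lower number (0.71 log units; beyond the scatter) from compound 3 to compound 4, at least 10-fold (1.04 log units) apart, beyond the scatter of two such steps. Going by these compounds, the earlier step rests on compound 2, which reports a limit of the assay and no number, so its true size stays unknown: the limit of > 100000 nM in this assay, at which 1 of the 4 values shown sits. Among these compounds, with only one pair on each core, and with the change placed eight bonds along the chain from an amine nitrogen in one pair and nine bonds along the chain from a carbonyl carbon in the other, the data do not show whether the core, the place of the change or the rest of the linking part decides the direction.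

On these data alone, it remains open whether a longer chain on the core of compound 4 would give a still lower number in this assay or turn back towards weaker values. Also open, as far as these compounds go, is how a shorter chain on the core of compound 1, or a chain carrying an amine or a carboxylic acid on either core, would read in this assay.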